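Pyrimidine and purine nucleoside analogues: cytotoxicity notes

A few compounds are considered here, and "the series" means these few. Any claim that something is new, unique, unknown or untested is made for them only; others in the source may bear on it.

Three compounds have numbers or limits; one awaits measurement. Compound 1 `C=C(Br)[C@H]1O[C@@H](n2cnc3c(N)ncnc32)[C@@H](O)[C@H]1O` gives 25000 nM in an ADME assay on L1210/0 cells (Mus musculus) for cytotoxicity, with a stated time of 48 h; a lower number here means a stronger inhibitor, a higher number a weaker inhibitor. Compound 2 `[N-]=[N+]=NCc1cn([C@H]2C[C@H](O)[C@@H](CO)O2)c(=O)[nH]c1=O` gives 124000 nM in this assay, the highest of the two numbers available; its nearest neighbour is compound 1, whose number is lower by a margin beyond the usual scatter. Compound 3 `CC1(C)C(CO)CC1Cn1nnc2c(Cl)nc(N)nc21` returns only a limit in this assay, > 200000 nM, which is the limit of > 200000 nM in this assay, at which 1 of the 3 values shown sits. No pair among these three differs in a single place, so no measured step exists in the set.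

Compound 4 `CC(C)(C)C#Cc1cn([C@H]2C[C@H](O)[C@@H](CO)O2)c(=O)[nH]c1=O` is the next candidate for this assay. Its change from compound 2: 3,3-dimethylbut-1-yn-1-yl in place of azidomethyl on an aromatic carbon. For the measured compounds named here, the data hold no step of this kind on which a direction could rest. The step expected is a 1.2-fold higher number from compound 2 to compound 4 (0.08 log units; within the scatter), no larger than the scatter. Compound 4 is accordingly estimated at 150000 nM, within 30000 nM to 600000 nM, with a real chance that only a limit is reported.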

Compound 4, half-maximal inhibitory concentration: > 200000 nM
Compound 4: only a limit was reported (the forecaster's own chance of this, stated with the estimate: 40%); at least 1.3-fold (0.12 log units) between middle value and limit.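

For the compounds shown here, the first measured step at this aromatic carbon, 3,3-dimethylbut-1-yn-1-yl in place of azidomethyl, reads in this assay as an at least 1.6-fold higher number from compound 2 to compound 4 (0.20 log units; that floor lies within the scatter). The floor of this step lies within the scatter, yet the exchange on the shared core brought no lower number, and the all-carbon alkynyl group is thus tolerated no better than azidomethyl in this read-out. Compound 4 gives > 200000 nM, which is a limit and not a number, and the series now holds two compounds at that limit: the limit of > 200000 nM in this assay, at which 2 of the 4 values shown sit.

From the compounds shown here alone, the true size of the step stays unknown, as does the distance of compound 4 from its limit. Whether an aminomethyl group or a carboxylic acid on the same aromatic carbon would give a lower number than azidomethyl is left open by the compounds shown.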